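This account rests on a few compounds, and the source may have more. Where it says the series, first, only, none or still open, it means among the compounds named here.

Compound 1 `CCCCCC(=O)c1ccc(O)cc1` gives 18000 nM in an assay on isolated protein for inhibition of 17-beta-hydroxysteroid dehydrogenase type 3 (Homo sapiens); a higher number here means a weaker inhibitor, a lower number a stronger inhibitor.
Compound 2 `CCCCCCCC(=O)c1ccc(O)cc1` gives 6520 nM in this assay.
Compound 3 `CCCCCCCCCC(=O)c1ccc(O)cc1` gives 4970 nM in this assay.

Among these three, compound 3 carries the lowest number in this assay, although its gap to compound 2 lies within the scatter; only its distance from compound 1 is beyond it. Compound 4 `CCCCCCCCCCCC(=O)c1ccc(O)cc1` has not yet been measured. It differs from compound 3 by ethyl in place of hydrogen on a saturated chain carbon, nine bonds along the chain from a carbonyl carbon. Going by the values given here, two measured steps bear directly on this change: a 2.8-fold lower number from compound 1 to compound 2 (0.44 log units; beyond the scatter) and a 1.3-fold lower number from compound 2 to compound 3 (0.12 log units; within the scatter); the combined change, a 3.6-fold lower number from compound 1 to compound 3 (0.56 log units; beyond the scatter), points the same way. Each lengthening of the chain so far has lowered the number, but the second lengthening gave a much smaller step than the first, one that stayed within the scatter. Since the change from compound 3 to compound 4 is a further lengthening of the same kind, the expected step in this assay is small, in the direction of a lower number, and quite possibly not beyond the scatter: a 1.2-fold lower number from compound 3 to compound 4 (0.09 log units; within the scatter). Compound 4 is therefore estimated at 4000 nM, with a likely range from 2000 nM to 8000 nM.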

Compound 4, half-maximal inhibitory concentration: 7550 nM
Estimate against measurement, compound 4: 1.9-fold (0.28 log units) below; the measured number falls inside the stated range.
By their numbers in this assay, from the lowest: compounds 3, 2 and 4 (each within the scatter of the next); then compound 1.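

In this assay, lengthening the chain beyond compound 3 brings no further lowering of the number: ethyl in place of hydrogen nine bonds along the chain from a carbonyl carbon gives a 1.5-fold higher number from compound 3 to compound 4 (0.18 log units; within the scatter), and butyl in place of hydrogen seven bonds along gives a 1.2-fold higher number from compound 2 to compound 4 (0.06 log units; within the scatter), so compounds 2, 3 and 4 cannot be told apart. The difference from the shortest chain remains, at a 2.4-fold lower number from compound 1 to compound 4 (0.38 log units; beyond the scatter), but the ethyl change no longer reads the same at every place along the chain: the same change on two cores in this assay, a 2.8-fold lower number (0.44 log units; beyond the scatter) from compound 1 to compound 2 and a 1.5-fold higher number (0.18 log units; within the scatter) from compound 3 to compound 4, 4.2-fold (0.62 log units) apart, beyond the scatter of two such steps The butyl change likewise depends on where along the chain it is made: the same change on two cores in this assay, a 3.6-fold lower number (0.56 log units; beyond the scatter) from compound 1 to compound 3 and a 1.2-fold higher number (0.06 log units; within the scatter) from compound 2 to compound 4, 4.2-fold (0.62 log units) apart, beyond the scatter of two such steps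

Going by these compounds, it remains open whether a longer chain than that of compound 4 would hold the number at this level or raise it beyond the scatter. On these data alone, it is also open what an amine or a carboxylic acid carried on the chain would do in this assay.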